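Ester Swap Toward a Morpholine Amide at the Half-Life Ceiling

The source may report more compounds than this note shows. Statements on the series, on what has been measured and on what is new or still open speak of the compounds shown alone.

Compound 1 `CCOc1cc(NC(=O)C2(NC(=O)c3ccc4c(C5CCCC5)c(-c5ncc(Cl)cn5)n(C)c4c3)CCC2)ccc1/C=C/C(=O)N[C@@H](CCC(=O)O)C(N)=O` gives 4.23 h in an ADME assay for pharmacokinetics, in simulated intestinal fluid; on this read-out higher numbers stand for a longer-lived compound and lower numbers for a shorter-lived compound. Compound 2 `CCCOC(=O)/C=C/c1ccc(NC(=O)C2(NC(=O)c3ccc4c(C5CCCC5)c(-c5ncc(Cl)cn5)n(C)c4c3)CCC2)cc1OCC` reaches > 5 h in this assay, which is a limit of the assay rather than a number. Compound 3 `CCOc1cc(NC(=O)C2(NC(=O)c3ccc4c(C5CCCC5)c(-c5ncc(Cl)cn5)n(C)c4c3)CCC2)ccc1/C=C/C(=O)OCc1ccccc1` likewise gives > 5 h, again only a limit. Across the group, an at least 1.1-fold higher number from compound 1 to compound 2 (0.07 log units; that floor lies within the scatter) and an at least 1.1-fold higher number from compound 1 to compound 3 (0.07 log units; that floor lies within the scatter), while a step that the two limits leave unreadable from compound 2 to compound 3; the reason both later values cannot be ordered is the limit of > 5 h in this assay, at which 2 of the 3 values shown sit. Compound 3 thus stands at the upper edge of what the assay reports, alongside compound 2.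

Compound 4 `CCOc1cc(NC(=O)C2(NC(=O)c3ccc4c(C5CCCC5)c(-c5ncc(Cl)cn5)n(C)c4c3)CCC2)ccc1/C=C/C(=O)OCC(=O)N1CCOCC1` carries (morpholin-4-yl)carbonyl in place of phenyl on a saturated chain carbon bound to an oxygen next to a carbonyl group. Among the measured compounds shown here, the only prior change at that same position, from compound 2 to compound 3, left no readable step, and the two changes from compound 1 that lifted the value to the limit both touched a different part of the side chain. For the measured compounds named here, no measured step therefore gives a direction for this change beyond the scatter. For compound 4 the expected half-life is 4.5 h, with a range from 2.5 h to 8 h. The step this estimate implies is an at least 1.1-fold lower number from compound 3 to compound 4 (0.04 log units; that floor lies within the scatter).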

Compound 4, half-life: 3.17 h
Beside the measured number, compound 4's estimate is 1.4-fold (0.15 log units) above it; the measured number falls inside the stated range.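

Among the compounds shown here, of the three compounds changed on this saturated chain carbon, compound 4 alone gives 3.17 h in this assay and not a limit, so (morpholin-4-yl)carbonyl is the only group here with a readable value. The result gives an at least 1.5-fold lower number from compound 3 to compound 4 (0.19 log units; that floor lies within the scatter) and an at least 1.5-fold lower number from compound 2 to compound 4 (0.19 log units; that floor lies within the scatter) as floors only, and their full size stays unreadable because the other two values are limits: the limit of > 5 h in this assay, at which 2 of the 4 values shown sit. Set against the (1-carbamoyl-3-carboxypropyl)amino group, the ((morpholin-4-yl)carbonyl)methoxy group gives a 1.3-fold lower number from compound 1 to compound 4 (0.13 log units; within the scatter) so a change at this carbonyl carbon does not by itself bring a compound to the limit.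

The step between the ethyl and phenyl compounds still cannot be read, so those two groups stay unordered. From the compounds shown here alone, whether an amine, a carboxylic acid or a longer chain on this carbon would give a number or stay at the limit remains open.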